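This account rests on a few compounds, and the source may have more. Where it says the series, first, only, none or still open, it means among the compounds named here.

Results so far in an ADME assay on HEK293 cells (Homo sapiens) for cytotoxicity, read by resazurin assay, with a stated time of 48 h; on this read-out higher numbers stand for lower toxicity in this test and lower numbers for higher toxicity in this test:

- compound 1 `O=S(=O)(Nc1ccc(-c2nc3ccccc3o2)cc1)c1cccc(F)c1` gives > 100000 nM as a limit
- compound 2 `O=S(=O)(Nc1ccc2oc(-c3ccccc3)nc2c1)c1cccc(F)c1` gives 68000 nM as a number
- compound 3 `O=S(=O)(Nc1ccc2oc(-c3ccccc3)nc2c1)c1ccc(Cl)c(C(F)(F)F)c1` gives 66000 nM as a number

Compound 1 records > 100000 nM in this test, which is a limit of the assay and not a number. That leaves two true numbers to compare. Compound 2 at 68000 nM and compound 3 at 66000 nM lie within the usual scatter of each other, so neither can be ranked over the other.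

Compound 4 `O=S(=O)(Nc1ccc2oc(-c3ccccc3)nc2c1)c1ccccc1Cl` is the compound still to be measured. Compared with compound 2, it carries 2-chlorophenyl in place of 3-fluorophenyl on a sulfonyl sulfur and is otherwise unchanged.

For the measured compounds named here, no two measured compounds differ in only one place, so there is no direct precedent for this swap. The nearest guide is the closeness of the two numbers already in hand, and so no step beyond the scatter is expected in this assay. The estimated change, a 1.1-fold lower number from compound 2 to compound 4 (0.05 log units; within the scatter), is expected to be small. Compound 4 is estimated at 60000 nM, with an expected range from 30000 nM to 100000 nM.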

Compound 4, half-maximal cytotoxic concentration: 73000 nM
For compound 4 the middle estimate is 1.2-fold (0.09 log units) below the measured one; the measured number falls inside the stated range.
By their numbers in this assay, from the lowest: compounds 3, 2 and 4 (each within the scatter of the next). At a limit, above all of these: compound 1.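

In this assay, compound 2 and compound 4 form the first pair shown that differs in only one place, so this swap of 2-chlorophenyl in place of 3-fluorophenyl on a sulfonyl sulfur can now be read directly: a 1.1-fold higher number from compound 2 to compound 4 (0.03 log units; within the scatter). The step lies within the usual scatter, so this pair shows no readable difference in toxicity in this test, even though both the halogen and the name of the group change. This reading applies only to this pair and to this part of the scale, and the test also has an upper end that one compound has already reached: the limit of > 100000 nM in this assay, at which 1 of the 4 values shown sits.

Going by these compounds, both groups in the pair are halogen-bearing phenyl rings, so it remains open how the test would respond to something of a different kind on the sulfonyl sulfur, such as an aminophenyl group, a carboxylic acid on the ring or a plain alkyl chain. On these data alone, it also remains open whether the same swap would read the same way on the core of compound 1.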